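Cyclopentyl in place of methoxyphenyl on the alkenyl chain

This account rests on a few compounds, and the source may have more. Where it says the series, first, only, none or still open, it means among the compounds named here.

Compound 1, `COc1cccc([C@H](O)[C@H]2CO[C@H](c3ccc(OC)c(OC)c3)[C@@H](C/C=C/c3ccc(OC)c(OC)c3)C2)c1`, in a functional assay on HeLa cells (Homo sapiens) for cytotoxicity, read by WST assay, with a stated time of 48 h; on this read-out higher numbers stand for weaker inhibition and lower numbers for stronger inhibition: 21200 nM
Compound 2, `COc1ccc(/C=C/C[C@@H]2C[C@@H]([C@@H](O)c3ccc(OC)c(OC)c3)CO[C@H]2c2ccccc2)cc1OC`, in this assay: 16100 nM
Compound 3, `COc1ccccc1/C=C/C[C@H]1C[C@@H]([C@@H](O)c2ccccc2)CO[C@@H]1c1ccccc1`, in this assay: 14700 nM

Compound 3 carries the lowest number of the three, but its gap to compound 2 and its gap to compound 1 both sit within the scatter of repeated measurements, so the three measured compounds are not separated from one another in this assay. Among the measured compounds shown here, none of them differs from another in a single place, so no measured step is available for this series.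

Compound 4, `O[C@@H](c1ccccc1)[C@H]1CO[C@H](c2ccccc2)[C@@H](C/C=C/C2CCCC2)C1`, differs from compound 3 in one place: cyclopentyl in place of 2-methoxyphenyl on a double-bonded chain carbon bound to a double-bonded chain carbon. For the measured compounds named here, the three measured compounds differ from each other at several places across their aryl groups and still give numbers within the scatter of each other, which is the only guide here. On that basis the step of a 1.3-fold higher number from compound 3 to compound 4 (0.11 log units; within the scatter) is expected to be none beyond the scatter, with a slight lean toward a higher number. For compound 4 the estimate is 19000 nM, with a range from 8000 nM to 45000 nM.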

Compound 4, half-maximal inhibitory concentration: 9330 nM
Estimate against measurement, compound 4: 2.0-fold (0.31 log units) above, and the stated range covers the measured number.
By their numbers in this assay, from the lowest: compounds 4, 3, 2 and 1 (each within the scatter of the next, the first and the last beyond it).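

Among the compounds shown here, this is the first single-place comparison, and it sits on the alkenyl chain: in this assay, the step is a 1.6-fold lower number from compound 3 to compound 4 (0.20 log units; within the scatter). At this position, on a double-bonded chain carbon bound to a double-bonded chain carbon, 2-methoxyphenyl can give way to cyclopentyl, so the aromatic ring and its methoxy oxygen both go, without the number leaving the scatter. Nothing available explains this result.

Open, going by these compounds, is whether other groups at the same place, such as cyclohexyl, unsubstituted phenyl, a straight pentyl chain or a chain ending in an amine, would also stay within the scatter of compound 3. Also open, on these data alone, is whether cyclopentyl at this position behaves the same way on the cores of compound 1 and compound 2, with their additional methoxy groups.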